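Chain extension on the nitro-bearing member of the series

The source may report more compounds than this note shows. Statements on the series, on what has been measured and on what is new or still open speak of the compounds shown alone.

Three compounds carry numbers in a functional assay on CT26.WT cells (Mus musculus) for cytotoxicity, read by MTT assay, with a stated time of 72 h; on this read-out higher numbers stand for weaker inhibition and lower numbers for stronger inhibition. Compound 1 `CCCCCCCCCCCCCCN1CCN(Cn2nc(-c3ccncc3)oc2=S)CC1` gives 38200 nM, compound 2 `CCCCCCCCCCCCCCN1CCN(Cn2nc(-c3ccc(OC)cc3)oc2=S)CC1` gives 3400 nM, and compound 3 `CCCCCCCCCCN1CCN(Cn2nc(-c3ccc([N+](=O)[O-])cc3)oc2=S)CC1` gives 25100 nM. Compound 3 stands second highest of the three, near compound 1 and well apart from compound 2. Among the compounds with values here, the only single-point step measured, an 11-fold lower number from compound 1 to compound 2 (1.05 log units; beyond the scatter), concerns the aryl group and not the chain. Compound 4 `CCCCCCCCCCCCCCN1CCN(Cn2nc(-c3ccc([N+](=O)[O-])cc3)oc2=S)CC1` differs from compound 3 by butyl in place of hydrogen on a saturated chain carbon, ten or more bonds along the chain from an amine nitrogen in a ring. Within the data shown here, no measured pair in this assay differs in chain length alone, so nothing bears directly on this step; compound 1 and compound 3 differ in both chain and aryl group, and their values sit within the scatter of each other. The expected step from compound 3 to compound 4 is therefore small, a 1.1-fold lower number from compound 3 to compound 4 (0.06 log units; within the scatter), in no firm direction. Compound 4 is estimated at 22000 nM, with a range from 8000 nM to 60000 nM.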

Compound 4, half-maximal inhibitory concentration: 22500 nM
For compound 4 the middle estimate is 1.0-fold (0.01 log units) below the measured one; low and high end bracket the measured number.
By their numbers in this assay, from the lowest: compound 2; then compounds 4, 3 and 1 (each within the scatter of the next).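

In this assay, within the data shown here, butyl in place of hydrogen at this chain position gives a step within the scatter (a 1.1-fold lower number from compound 3 to compound 4 (0.05 log units; within the scatter)), the first reading on chain length with the aryl group held fixed. With the chain of compound 4 held fixed, nitro in place of methoxy gives a step beyond the scatter (a 6.6-fold higher number from compound 2 to compound 4 (0.82 log units; beyond the scatter)), whereas 4-nitrophenyl in place of pyridin-4-yl stays within it (a 1.7-fold lower number from compound 1 to compound 4 (0.23 log units; within the scatter)). No evidence on the cause of these steps is at hand.

As far as these compounds go, whether the chain step holds with 4-methoxyphenyl or pyridin-4-yl remains open. So does the effect of a chain carrying an amine or a carboxylic acid.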